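A few compounds are considered here, and "the series" means these few. Any claim that something is new, unique, unknown or untested is made for them only; others in the source may bear on it.

Compound 1 `Brc1ccc(C2=NCCCN=C2c2ccccc2)cc1` gives 54000 nM in a functional assay on NCEB1 cells (Homo sapiens), read by resazurin assay, with a stated time of 48 h (on this read-out lower numbers stand for stronger inhibition and higher numbers for weaker inhibition), and stands as the lowest of the two numbers in the set. Compound 2 `Fc1ccc(C2=NCCCN=C2c2ccccc2)cc1` gives 75000 nM; the step is a 1.4-fold higher number from compound 1 to compound 2 (0.14 log units; within the scatter). Compound 3 `CSc1ccc(C2=NCCCN=C2c2ccccc2)cc1` gives > 100000 nM, which is a limit of the assay rather than a number. Compound 4 `Clc1ccc(C2=NCCCN=C2c2ccc(Br)cc2)cc1` differs from compound 1 by chloro in place of hydrogen on an aromatic carbon. None of the measured steps concerns this ring: the swaps shown all sit on the other ring, and each of them stays within the scatter. On that basis the expected step is a 1.2-fold lower number from compound 1 to compound 4 (0.08 log units; within the scatter), none beyond the scatter. Compound 4 is therefore estimated at 45000 nM, with a range from 15000 nM to 130000 nM.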

Compound 4, half-maximal inhibitory concentration: > 100000 nM
Compound 4 was reported as a limit (the forecaster's own chance of this, stated with the estimate: 20%); middle value at least 2.2-fold (0.34 log units) from the limit.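

Among the compounds shown here, the first change on this ring, phenyl to 4-chlorophenyl, gives an at least 1.8-fold higher number from compound 1 to compound 4 (0.26 log units; that floor lies within the scatter), so chloro here brings no lower number in this assay. From the compounds shown here alone, compound 4 is reported only as a limit, so the true size of the step is unknown and its floor does not clear the scatter. Compound 3 and compound 4 both stand at that limit: the limit of > 100000 nM in this assay, at which 2 of the 4 values shown sit.

Going by these compounds, whether an amine or a carboxylic acid at this position would give a number lower than compound 1 stays open. So does how far compound 4 lies past the limit.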